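The source may hold more compounds than are shown below. What is called first, only, known or untested is meant among the compounds shown, and "the series" means these compounds.

Measured compounds:
Compound 1 `O=C(CSC(=S)N[C@H]1CCOC1=O)Nc1ccc(Br)cc1`; in a functional assay on MGC-803 cells (Homo sapiens) for cytotoxicity, read by MTT assay, with a stated time of 72 h (a lower number here means a stronger inhibitor, a higher number a weaker inhibitor), compound 1 gives 42800 nM.
Compound 2 `O=C(CSC(=S)N[C@H]1CCOC1=O)Nc1ccccc1`; in this assay compound 2 gives 39700 nM.
Compound 3 `O=C(CSC(=S)N[C@H]1CCOC1=O)Nc1ccc(C(=O)/C=C/c2ccccc2)cc1`; in this assay compound 3 gives 24800 nM.

The cores of compound 2 and compound 3 differ by (2-phenylethenyl)carbonyl in place of hydrogen on an aromatic carbon, with the step of a 1.6-fold lower number from compound 2 to compound 3 (0.20 log units; within the scatter). Compound 1 differs from compound 2 by bromo in place of hydrogen on an aromatic carbon, and the step of a 1.1-fold higher number from compound 2 to compound 1 (0.03 log units; within the scatter).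

Compound 4 `O=C(CSC(=S)N[C@H]1CCOC1=O)Nc1ccc(C(=O)/C=C/c2ccc(Br)cc2)cc1` is not yet measured. It differs from compound 3 by bromo in place of hydrogen on an aromatic carbon. This is the same kind of change as that from compound 2 to compound 1, set on the same kind of place, though here the group carrying it reads phenyl to 4-bromophenyl within the 2-phenylethenyl group rather than on the core's own ring. Because the earlier step of a 1.1-fold higher number from compound 2 to compound 1 (0.03 log units; within the scatter) stayed within the scatter, the step expected in this assay is a 1.1-fold lower number from compound 3 to compound 4 (0.03 log units; within the scatter). Compound 4 is thus estimated at 23000 nM, between 10000 nM and 55000 nM.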

Compound 4, half-maximal inhibitory concentration: 19600 nM
The estimate for compound 4 lay 1.2-fold (0.07 log units) above the measured number; the range from low to high includes it.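

In this assay, bromo in place of hydrogen on an aromatic carbon, read here as phenyl to 4-bromophenyl, gives a 1.3-fold lower number from compound 3 to compound 4 (0.10 log units; within the scatter). Set beside the same change on the other core, the two steps do not differ: the same change on two cores in this assay, a 1.1-fold higher number (0.03 log units; within the scatter) from compound 2 to compound 1 and a 1.3-fold lower number (0.10 log units; within the scatter) from compound 3 to compound 4, 1.4-fold (0.13 log units) apart, within the scatter of two such steps. Among these compounds, this shows that the change stayed small on both cores, but with only two pairs, neither step beyond the scatter, it does not show a rule for other cores or that bromo would stay without effect elsewhere.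

Still open, going by these compounds, is whether a different group in place of bromo, such as an amine, a carboxylic acid or a methoxy group, would give a step beyond the scatter. Also open, on these data alone, is whether such a step would carry from one core to the other.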